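Ethoxycarbonyl in place of iodo: compound 2 to compound 4

The source may hold more compounds than are shown below. What is called first, only, known or untested is meant among the compounds shown, and "the series" means these compounds.

Compound 2 `O=C(/C=C/c1ccc2c(c1)B(O)OC2)c1ccc(I)cc1` gives 14900 nM in a functional assay on MDA-MB-231 cells (Homo sapiens) for cytotoxicity, read by MTT assay, with a stated time of 48 h (on this read-out higher numbers stand for weaker inhibition and lower numbers for stronger inhibition), the highest number among the three measured compounds; its nearest neighbour is compound 3 `O=C(/C=C/c1ccc2c(c1)B(O)OC2)c1ccc(OCc2ccccc2)cc1`, which gives 5300 nM, and the furthest is compound 1 `O=C(/C=C/c1ccc2c(c1)B(O)OC2)c1ccc(F)cc1`, which gives 1600 nM. Compound 4 `CCOC(=O)c1ccc(C(=O)/C=C/c2ccc3c(c2)B(O)OC3)cc1` has not yet been measured. It differs from compound 2 in one place: ethoxycarbonyl in place of iodo on an aromatic carbon. Among the compounds with values here, two measured steps bear on a change at this carbon. The step of a 2.8-fold lower number from compound 2 to compound 3 (0.45 log units; beyond the scatter) shows that benzyloxy in place of iodo lowers the number, and the step of a 9.3-fold higher number from compound 1 to compound 2 (0.97 log units; beyond the scatter) shows that iodo in place of fluoro raises it, so in both cases iodo on this carbon carries the highest number. Ethoxycarbonyl has no measured precedent in this series, so the size of its effect rests only on these two steps. A lower number than compound 2, beyond the scatter, is expected, and the expected step is a 3.0-fold lower number from compound 2 to compound 4 (0.47 log units; beyond the scatter). Compound 4 is expected to give 5000 nM, with a range from 1500 nM to 16000 nM.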

Compound 4, half-maximal inhibitory concentration: 13000 nM
Estimate against measurement, compound 4: 2.6-fold (0.41 log units) below; the measured number falls inside the stated range.
By their numbers in this assay, from the lowest: compound 1; then compound 3; then compounds 4 and 2 (each within the scatter of the next).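

In this assay ethoxycarbonyl on this aromatic carbon cannot be told apart from iodo (a 1.1-fold lower number from compound 2 to compound 4 (0.06 log units; within the scatter)), so iodo no longer stands alone at the weak end of the series, and the heavy-atom count, one for iodo and five for ethoxycarbonyl, does not separate the two groups. Ethoxycarbonyl also sits clearly on the weaker side of both remaining groups (a 2.5-fold higher number from compound 3 to compound 4 (0.39 log units; beyond the scatter); an 8.1-fold higher number from compound 1 to compound 4 (0.91 log units; beyond the scatter)), which leaves fluoro, then benzyloxy, then ethoxycarbonyl and iodo together as the order at this position. Nothing in the data accounts for this order.

Open, from the compounds shown here alone, is whether a carboxylic acid, an amine or a longer ester chain on this carbon would join compounds 2 and 4 or move toward compound 1. Also open, going by these compounds, is whether chloro or methoxy would give a lower number than fluoro.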